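The source may report more compounds than this note shows. Statements on the series, on what has been measured and on what is new or still open speak of the compounds shown alone.

Notes on the series. In an ADME assay on L02 cells (Homo sapiens) for inhibition, read by CCK-8 assay, with a stated time of 48 h (a lower number here means a stronger inhibitor of growth, a higher number a weaker inhibitor of growth), compound 1 `Cc1ccccc1Nc1nc(Nc2cc(Cl)ccn2)ncc1Cl` gives 41500 nM, and compound 2 `Cc1ccccc1Nc1nc(Nc2ccc(N3CCNCC3)cn2)ncc1Cl` gives 1850 nM. Compound 3 `CN1CCN(c2ccc(Nc3ncc(Cl)c(Nc4ccccc4)n3)nc2)CC1` gives 7990 nM, the second highest of the three numbers and beyond the scatter from both of the others. Compound 4 `COc1ccccc1CNc1nc(Nc2ccc(N3CCN(C)CC3)cn2)ncc1Cl` has 2-methoxybenzyl in place of phenyl on a nitrogen on an aromatic ring. Within the data shown here, no measured pair differs by one change alone, so nothing here gives the size of this step directly. No step beyond the scatter is expected in this assay, with wide uncertainty in either direction. The estimated change is small: a 1.1-fold lower number from compound 3 to compound 4 (0.06 log units; within the scatter). The expected value for compound 4 is 7000 nM, with an estimated range of 2300 nM to 21000 nM.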

Compound 4, concentration for 50% growth inhibition: 25500 nM
Compound 4: middle estimate off by 3.6-fold (0.56 log units), on the low side, and the stated range ends below it.
By their numbers in this assay, from the lowest: compound 2; then compound 3; then compounds 4 and 1 (each within the scatter of the next).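

In this assay, among these compounds, anilino to (2-methoxybenzyl)amino gives a 3.2-fold higher number from compound 3 to compound 4 (0.50 log units; beyond the scatter) on the shared core, the first step that isolates a single change. The group on this nitrogen therefore affects the read-out, and this replacement goes with weaker growth inhibition. Nothing measured here bears on the cause of this step. The compounds shown leave open whether the step follows the methoxy group or the extra carbon link of the benzyl. A plain benzyl or a 2-methoxyphenyl on this nitrogen would separate the two.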